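The compounds below may be only part of what the source reports. "The series", "measured", "known", "first", "only" and "open" are said of these compounds alone.

Measured compounds:
compound 1 `OC[C@H]1O[C@@H](n2cnc3c(NCc4ccco4)ncnc32)[C@H](O)[C@@H]1O` — 36300 nM
compound 2 `OC[C@H]1O[C@@H](n2cnc3c(CSc4c(F)cccc4Cl)ncnc32)[C@H](O)[C@@H]1O` — 1510 nM
compound 3 `OC[C@H]1O[C@@H](n2cnc3c(CSc4ccccc4F)ncnc32)[C@H](O)[C@@H]1O` — 355 nM

In an assay on isolated protein for binding affinity to Equilibrative nucleoside transporter 1 (Homo sapiens) (a higher number here means a weaker inhibitor, a lower number a stronger inhibitor), compound 3 gives 355 nM, the lowest of the three numbers. Compound 2 is nearest, and the step of a 4.3-fold lower number from compound 2 to compound 3 (0.63 log units; beyond the scatter) is modest but beyond the scatter. Compound 1 is furthest, with the large step of a 100-fold lower number from compound 1 to compound 3 (2.01 log units; beyond the scatter).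

Compound 4 `OC[C@H]1O[C@@H](n2cnc3c(CSc4ccc(Br)cc4)ncnc32)[C@H](O)[C@@H]1O` differs from compound 3 in one place: 4-bromophenyl in place of 2-fluorophenyl on a sulfur. Among the measured compounds shown here, no measured step bears directly on this change. The step of a 4.3-fold lower number from compound 2 to compound 3 (0.63 log units; beyond the scatter) shows that adding a second halogen to the phenyl ring of compound 3 made the number higher, but nothing measured shows what moving a single halogen from one position on that ring to another does, nor what exchanging fluorine for bromine does. The step of a 100-fold lower number from compound 1 to compound 3 (2.01 log units; beyond the scatter) concerns a different part of the structure and is not relevant here.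

The expectation for compound 4 in this assay therefore rests on compound 3 alone, with a wide range: the step of a 2.3-fold higher number from compound 3 to compound 4 (0.35 log units; beyond the scatter) is estimated to be small, with the number expected to be somewhat higher. Compound 4 is expected to give about 800 nM, most likely between 150 nM and 4500 nM.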

Compound 4, half-maximal inhibitory concentration: 178 nM
Compound 4: the middle estimate sits 4.5-fold (0.65 log units) above what was measured; low and high end bracket the measured number.
By their numbers in this assay, from the lowest: compounds 4 and 3 (each within the scatter of the next); then compound 2; then compound 1.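

In this assay, the exchange of 2-fluorophenyl for 4-bromophenyl on the sulfur stays within the scatter (a 2.0-fold lower number from compound 3 to compound 4 (0.30 log units; within the scatter)), so a single halogen on this ring changed both its identity and its place with no readable shift in the number. Set against the 2-chloro-6-fluorophenyl group of compound 2, the 4-bromophenyl group gives a modest step beyond the scatter (an 8.5-fold lower number from compound 2 to compound 4 (0.93 log units; beyond the scatter)), which places compound 4, like compound 3, apart from compound 2. The large step away from the ((furan-2-yl)methyl)amino group of compound 1 (a 200-fold lower number from compound 1 to compound 4 (2.31 log units; beyond the scatter)) now holds for a second ((aryl)sulfanyl)methyl compound, with a different ring on the sulfur.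

Nothing available explains why these two single-halogen rings read alike in this assay. Still open, on these data alone, is what a 4-fluorophenyl or a 2-bromophenyl group on the sulfur would give, which would separate the identity of the halogen from its place, and what a ring carrying an amine or a carboxylic acid would do.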